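Urea-linked quinoline analogues and cytotoxicity in Raji cells

The source may report more compounds than this note shows. Statements on the series, on what has been measured and on what is new or still open speak of the compounds shown alone.

Measured so far:
compound 1 `Cc1cc(NC(=O)Nc2ncccc2C)c2ccccc2n1`: > 25000 nM
compound 2 `CSc1ccccc1NC(=O)Nc1cc(C)nc2ccccc12`: > 25000 nM

In an ADME assay on Raji cells (Homo sapiens) for cytotoxicity, with a stated time of 72 h (a lower number here means that less compound is needed, a higher number that more compound is needed for the effect), compound 1 gives > 25000 nM, which is a limit of the assay and not a number. Compound 2 likewise reaches only > 25000 nM, again a limit. Compound 1 therefore stands at the limit of > 25000 nM in this assay, at which 2 of the 2 values shown sit, with no measured number to place it. Compound 3 `Cc1cc(NC(=O)Nc2cccnc2)c2ccccc2n1` carries pyridin-3-yl in place of 3-methylpyridin-2-yl on an amide-type nitrogen. With both known values at a limit, the step from compound 1 to compound 3 is expected to be none beyond the scatter, written as a step that the limit leaves unreadable from compound 1 to compound 3. Compound 3 is thus estimated at 30000 nM, with a range from 8000 nM to 100000 nM.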

Compound 3, half-maximal effective concentration: > 25000 nM
Compound 3: no number, only a limit; the forecaster's own chance of this, stated with the estimate: 75%; the middle value does not contradict the limit.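

Among the compounds shown here, compound 1 and compound 3 both stand at a limit of the assay, and no step between them can be read. The compounds shown leave open how far each lies past that limit, and whether the exchange of groups on the amide-type nitrogen changes the read-out at all.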